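Swapping the group on the aromatic nitrogen of compound 1

The compounds below may be only part of what the source reports. "The series", "measured", "known", "first", "only" and "open" are said of these compounds alone.

Measured compounds:
compound 1 `CCOC(=O)C1=Cc2ccccc2OC1(OCc1cn(CC(=O)Nc2ccc(C)cc2)nn1)C(F)(F)F` – > 150000 nM
compound 2 `CCOC(=O)C1=Cc2ccccc2OC1(OCc1cc(-c2ccc3ccccc3c2)no1)C(F)(F)F` – 71800 nM

Compound 1 `CCOC(=O)C1=Cc2ccccc2OC1(OCc1cn(CC(=O)Nc2ccc(C)cc2)nn1)C(F)(F)F` was tested in a functional assay on DU-145 cells (Homo sapiens) for inhibition, read by MTT assay, with a stated time of 24 h; on this read-out higher numbers stand for weaker inhibition and lower numbers for stronger inhibition. For compound 1 the result is only a limit, > 150000 nM, so no number is known for it. Going by the values given here, compound 2 `CCOC(=O)C1=Cc2ccccc2OC1(OCc1cc(-c2ccc3ccccc3c2)no1)C(F)(F)F` is the only one of the pair with a measured number, giving 71800 nM in this assay. Compound 1 therefore sits at the weak end of what has been seen so far, as the evidence shows: the limit of > 150000 nM in this assay, at which 1 of the 2 values shown sits.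

Compound 3 `CCOC(=O)C1=Cc2ccccc2OC1(OCc1cn(-c2cccc(C(F)(F)F)c2)nn1)C(F)(F)F` has not been measured. It differs from compound 1 in one place: 3-(trifluoromethyl)phenyl in place of ((4-methylphenyl)carbamoyl)methyl on an aromatic nitrogen. The ((4-methylphenyl)carbamoyl)methyl group with its hydrogen-bond donor and acceptor is gone, and a 3-(trifluoromethyl)phenyl group with none of either sits on the aromatic nitrogen instead.

Among the compounds with values here, no measured step between related compounds is available to set the size of this change. The expectation is that compound 3 moves toward stronger inhibition in this assay, with an estimated step of an at least 1.5-fold lower number from compound 1 to compound 3 (0.17 log units; that floor lies within the scatter). Compound 3 is estimated to give 100000 nM, in a range from 30000 nM to 300000 nM.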

Compound 3, half-maximal inhibitory concentration: > 150000 nM
Compound 3 gave a limit, no number; the forecaster's own chance of this, stated with the estimate: 45%; middle value at least 1.5-fold (0.17 log units) away from the limit.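

Compound 1 and compound 3 are both reported only as limits rather than numbers, so no step can be read between them: the limit of > 150000 nM in this assay, at which 2 of the 3 values shown sit.

The compounds shown leave open whether 3-(trifluoromethyl)phenyl in place of ((4-methylphenyl)carbamoyl)methyl on the aromatic nitrogen changes inhibition in this assay at all, and if so, in which direction and by how much.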